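A few compounds are considered here, and "the series" means these few. Any claim that something is new, unique, unknown or untested is made for them only; others in the source may bear on it.

Compound 1 `O=C1C[C@H](O)CC(CCc2c(Cl)cc(Cl)c3cc(Cl)ccc23)O1` gives 33 nM in an assay on isolated protein for inhibition of 3-hydroxy-3-methylglutaryl-coenzyme A reductase (Rattus norvegicus); a higher number here means a weaker inhibitor, a lower number a stronger inhibitor.
Compound 2 `Cc1cc(Cl)c(CCC2C[C@@H](O)CC(=O)O2)c2cc(Cl)ccc12` gives 130 nM in this assay.

Of these two compounds, compound 2 has the higher number, and its gap to compound 1 lies beyond the usual scatter of such measurements, so compound 2 is the weaker inhibitor of the pair. Compound 3 `Cc1cc(C)c2ccc(Cl)cc2c1CCC1C[C@@H](O)CC(=O)O1` has not yet been measured. It differs from compound 2 in one place: methyl in place of chloro on an aromatic carbon. Among the measured compounds shown here, no measured pair shows the effect of exactly this exchange, so its direction cannot be read from the data at hand. Exchanging one such group for another on the aromatic ring is expected to give a modest step at most, with a slight drift toward a higher number as the more likely outcome. Compound 3 is therefore expected to give 200 nM in this assay, within a range from 60 nM to 700 nM. The step of a 1.5-fold higher number from compound 2 to compound 3 (0.19 log units; within the scatter) is expected to stay close to the scatter.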

Compound 3, half-maximal inhibitory concentration: 200 nM
Compound 3: the middle estimate sits on the measured number at the digits printed, and the stated range covers the measured number.
By their numbers in this assay, from the lowest: compound 1; then compounds 2 and 3 (each within the scatter of the next).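

The exchange of chloro for methyl on this aromatic carbon gives a 1.5-fold higher number from compound 2 to compound 3 (0.19 log units; within the scatter) in this assay and so leaves compound 2 and compound 3 indistinguishable in this measurement. At this position, ortho to a large group and meta to a methyl group, the chlorine is therefore not needed to keep the inhibition seen with compound 2, and a methyl serves equally well within the scatter. Nothing available here explains why these two groups read alike.

As far as these compounds go, whether this position accepts groups of a different kind, such as an amine, a carboxylic acid or a longer chain, remains open. A single pair also cannot show whether the same exchange would read alike elsewhere on the shared core.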